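The compounds below may be only part of what the source reports. "The series", "measured", "known", "first", "only" and "open" are said of these compounds alone.

Compound 1, `Clc1ccc(C2=CC3CNCC(C2)C3)cn1`: 152%
Compound 2, `COc1ccc(C2=CC3CC(C2)CN(C)C3)cn1`: 20%
Compound 3, `C1=C(c2cncc(Oc3ccccc3)c2)CC2CNCC1C2`: 30%

All three were tested in an in vitro functional assay on SH-EP1 cells for agonist activity at Neuronal acetylcholine receptor; alpha4/beta2 (Homo sapiens), read by FLIPR and calcium flux; on this read-out lower numbers stand for smaller maximal responses and higher numbers for larger maximal responses. Compound 1 gives the highest of the three numbers; compound 3 comes nearest and compound 2 furthest, both beyond the usual scatter. Compound 4, `C1=C(c2ccc(-c3ccccc3)nc2)CC2CNCC1C2`, has not yet been measured. It differs from compound 1 in one place: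

phenyl in place of chloro on an aromatic carbon

Going by the values given here, no pair of measured compounds shows this change, so there is no direct guide. Compound 2 and compound 3, which lack the chloro group, both sit far below compound 1. On that basis a drop is expected, a number 92 percentage points lower from compound 1 to compound 4 (beyond the scatter), and compound 4 is estimated at 60% in this assay, within a range from 15% to 130%.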

Compound 4, largest response reached (reported as percent of maximum), in percent of the reference or control that the assay uses: 18%
Beside the measured number, compound 4's estimate is 42 percentage points above it; the range from low to high includes it.
By their numbers in this assay, from the lowest: compounds 4, 2 and 3 (each within the scatter of the next, the first and the last beyond it); then compound 1.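

Placing phenyl instead of chloro on this aromatic carbon, next to the ring nitrogen, gives the first direct reading of a change at this position: in this assay the result is a number 134 percentage points lower from compound 1 to compound 4 (beyond the scatter). The large response of compound 1 therefore depends strongly on what sits here, and phenyl does not preserve it. Nothing available explains why the response falls.

On these data alone, it remains open whether fluoro, methyl or an amine at this position would keep the response. A single step also cannot show whether the loss comes from removing chloro or from adding phenyl.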